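A few compounds are considered here, and "the series" means these few. Any claim that something is new, unique, unknown or untested is made for them only; others in the source may bear on it.

Among the compounds with values here, in a functional assay on HeLa cells (Homo sapiens) for inhibition (a higher number here means a weaker inhibitor, a lower number a stronger inhibitor), compound 1 `CC(C)c1ccc(C(=O)CC(SCC(=O)O)C(=O)O)cc1` gives 3330 nM and compound 2 `CC(C)(C)c1ccc(C(=O)CC(SCC(=O)O)C(=O)O)cc1` gives 1390 nM; the single measured step, a 2.4-fold lower number from compound 1 to compound 2 (0.38 log units; beyond the scatter), is modest but beyond the scatter. Compound 2 thus holds the lower of the two numbers, with compound 1 the nearest. Compound 3 `O=C(O)CSC(CC(=O)c1ccc(Cl)cc1)C(=O)O` carries chloro in place of tert-butyl on an aromatic carbon. Within the data shown here, only the step from compound 1 to compound 2 concerns this position, and there adding methyl gave the lower number; taking the whole tert-butyl away for chloro therefore points the other way. Hence compound 3 is expected to show a 2.2-fold higher number from compound 2 to compound 3 (0.33 log units; beyond the scatter). For compound 3 in this assay the estimate is 3000 nM, within 1200 nM to 8000 nM.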

Compound 3, half-maximal inhibitory concentration: 17200 nM
Compound 3: middle estimate off by 5.7-fold (0.76 log units), on the low side, and the stated range ends below it.
By their numbers in this assay, from the lowest: compound 2; then compound 1; then compound 3.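

In this assay the swap to chloro weighs far more than the earlier addition of methyl, with a 12-fold higher number from compound 2 to compound 3 (1.09 log units; beyond the scatter) and a 5.2-fold higher number from compound 1 to compound 3 (0.71 log units; beyond the scatter) in the same direction. Across the three compounds the number rises in the order tert-butyl, isopropyl, chloro, and none goes against that order. Nothing available explains the size of these steps. On these data alone, whether the rise follows the loss of carbon atoms or the arrival of chlorine stays open, since chloro differs from both alkyl groups in both respects. A methoxy group or a longer alkyl chain at this position could help separate the two.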